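The compounds below may be only part of what the source reports. "The series", "measured", "known", "first", "only" and "open" are said of these compounds alone.

Measured so far in a functional assay on PC-6 cells (Homo sapiens) for antiproliferative activity; a lower number here means a stronger inhibitor, a higher number a weaker inhibitor:
- compound 1 `CCc1cc2c(N/N=C\C(C)(C)C)ncnc2s1` gives 1.55 ug/mL
- compound 2 `CC(C)c1cc2c(N/N=C\c3cccnc3)ncnc2s1` gives 0.889 ug/mL
- compound 3 `CC(C)(C)c1cc2c(N/N=C\c3cccnc3)ncnc2s1` gives 1.45 ug/mL

The three numbers lie within the usual scatter of one another, so compound 3 cannot be set apart from compound 1 or compound 2 on these values. For the measured compounds named here, the only step that exists between two measured compounds is a 1.6-fold higher number from compound 2 to compound 3 (0.21 log units; within the scatter); it changes the group on the shared core and stays within the scatter.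

Compound 4 `CC(C)(C)c1cc2c(N/N=C\c3cccc(CN)n3)ncnc2s1` differs from compound 3 by 6-(aminomethyl)pyridin-2-yl in place of pyridin-3-yl on a carbon with a double bond to nitrogen. Going by the values given here, no measured pair touches the hydrazone side in this way: compound 1 carries a saturated group there, compound 2 and compound 3 both carry pyridin-3-yl, and none of the measured compounds carries a hydrogen-bond donor on that side. So no measured step bears directly on this change. What the series shows is that a large change of the hydrazone group between compound 1 and compound 3 left the numbers within the scatter of each other, and the step from compound 2 to compound 3 was also within the scatter. The expectation for compound 4 is therefore a step of a 1.0-fold higher number from compound 3 to compound 4 (0.01 log units; within the scatter), that is none beyond the scatter, with a wide range to allow for the untested donor. Compound 4 is estimated at 1.5 ug/mL, between 0.5 ug/mL and 4.5 ug/mL.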

Compound 4, half-maximal inhibitory concentration: 0.036 ug/mL
Compound 4: the middle estimate sits 42-fold (1.62 log units) above what was measured, outside the stated range (below it).
By their numbers in this assay, from the lowest: compound 4; then compounds 2, 3 and 1 (each within the scatter of the next).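

In this assay, for the compounds shown here, the change of group on the carbon with a double bond to nitrogen gives a 40-fold lower number from compound 3 to compound 4 (1.61 log units; beyond the scatter), the only step that lies beyond the scatter, so this position can move the number strongly, which the earlier compounds did not show. The change is a single swap that alters where the pyridine ring is attached and also adds an aminomethyl group with a hydrogen-bond donor, so the step cannot be divided between these two differences. Nothing available here accounts for the size of the step.

On these data alone, it remains open whether the amine is needed at all: 6-methylpyridin-2-yl, 6-(hydroxymethyl)pyridin-2-yl or plain pyridin-2-yl on the same core would separate the contribution of the amine from that of the ring attachment. Also open, as far as these compounds go, is whether 6-(aminomethyl)pyridin-2-yl gives a step of this size with other groups on the shared core, such as the group carried by compound 2.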